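The compounds below may be only part of what the source reports. "The series", "measured", "known", "first", "only" and "open" are said of these compounds alone.

Going by the values given here, in a functional assay on RKO cells (Homo sapiens) for cytotoxicity, read by resazurin assay, with a stated time of 72 h (a lower number here means a stronger inhibitor, a higher number a weaker inhibitor), compound 1 `Cc1cn(-c2csc(Nc3ccc(Br)cc3)n2)c(C)n1` gives 45000 nM, the only true number among the measured compounds. Compound 2 `Brc1ccc(Nc2nc(-n3cnc4ccccc43)cs2)cc1` reads > 100000 nM, which is a limit of the assay. Compound 3 `Cc1nccn1-c1csc(Nc2ccc(Br)cc2)n1` reads > 100000 nM, also a limit. Compound 4 `Cc1ccc(Nc2nc(-n3cc(C)nc3C)cs2)cc1` differs from compound 1 in one place: methyl in place of bromo on an aromatic carbon. Among the compounds with values here, no measured step touches that position. The nearest guide is an at least 2.2-fold higher number from compound 1 to compound 3 (0.34 log units; beyond the scatter), a modest loss made elsewhere in the molecule, and little room remains for compound 1 with 45000 nM before (the limit of > 100000 nM in this assay, at which 2 of the 3 values shown sit). A small step toward weaker inhibition is therefore expected, and the expected step is a 1.3-fold higher number from compound 1 to compound 4 (0.12 log units; within the scatter). For compound 4 the estimated value is 60000 nM, with an expected range of 25000 nM to 100000 nM.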

Compound 4, half-maximal inhibitory concentration: > 100000 nM
Compound 4: only a limit was reported; the forecaster's own chance of this, stated with the estimate: 40%; at least 1.6-fold (0.22 log units) between middle value and limit.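

Going by these compounds alone, the earlier steps left the bromo untouched, so this is the first reading at that place. In this assay, methyl in place of bromo gives an at least 2.2-fold higher number from compound 1 to compound 4 (0.34 log units; beyond the scatter), so at this position the measurable activity of compound 1 does not survive the exchange. The true size of the loss cannot be read because compound 4 gives only a limit: the limit of > 100000 nM in this assay, at which 3 of the 4 values shown sit.

As far as these compounds go, whether a chloro, a methoxy or an amine at this place would keep the activity of compound 1 stays open.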